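Heteroaryl exchange on the saturated chain carbon of the series

The source may hold more compounds than are shown below. What is called first, only, known or untested is meant among the compounds shown, and "the series" means these compounds.

Of the compounds shown here, three of the shared core have been measured in a functional assay on U-266 cells (Homo sapiens) for inhibition, read by MTT assay, with a stated time of 48 h, tested at 0.1 uM; on this read-out higher numbers stand for more inhibition at the one concentration tested (going by the name of the read-out) and lower numbers for less inhibition. Compound 1 `Cc1noc(C)c1-c1ccc2c(c1)C(c1ccccc1)N(Cc1nnc(-c3ccccc3)o1)C(=O)N2C` gives 26.7%, compound 2 `Cc1nc(-c2ccccc2)sc1CN1C(=O)N(C)c2ccc(-c3c(C)noc3C)cc2C1c1ccccc1` gives 7.19%, and compound 3 `Cc1noc(C)c1-c1ccc2c(c1)C(c1ccccc1)N(Cc1nnc(-c3ccccc3)s1)C(=O)N2C` gives 20.3%. On these numbers compound 3 stands second highest of the three. Its gap to compound 1, a number 6.4 percentage points lower from compound 1 to compound 3 (within the scatter), lies within the scatter, so no order between those two is claimed; its gap to compound 2, a number 13.1 percentage points higher from compound 2 to compound 3 (beyond the scatter), is a modest difference beyond the scatter.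

Compound 4 `Cc1noc(C)c1-c1ccc2c(c1)C(c1ccccc1)N(Cc1nc(-c3ccccc3)cs1)C(=O)N2C` has not yet been measured. The change from compound 3 is 4-phenyl-1,3-thiazol-2-yl in place of 5-phenyl-1,3,4-thiadiazol-2-yl on a saturated chain carbon bound to an amide-type nitrogen in a ring. The measured steps that bear on this position are a number 19.5 percentage points lower from compound 1 to compound 2 (beyond the scatter), a number 13.1 percentage points higher from compound 2 to compound 3 (beyond the scatter) and a number 6.4 percentage points lower from compound 1 to compound 3 (within the scatter). The exchange of an oxadiazole for a thiadiazole at this carbon stayed within the scatter, while the compound carrying a thiazole, compound 2, gave the lowest number of the three. Compound 4 carries a thiazole of different substitution, so that step is only a loose guide. A modest fall from compound 3 is therefore expected, a number 6.3 percentage points lower from compound 3 to compound 4 (within the scatter), with a wide range. For compound 4 a value of 14% is estimated, expected to lie between 4% and 26%.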

Compound 4, a percentage reported as inhibition, at one concentration (the size of the read-out at that concentration, not a potency): 12.7%
Compound 4: middle estimate off by 1.3 percentage points, on the high side, and the stated range covers the measured number.
By their numbers in this assay, from the lowest: compounds 2, 4, 3 and 1 (each within the scatter of the next, the first and the last beyond it).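

Working notes on the thiazole exchange. In this assay, the exchange of 5-phenyl-1,3,4-oxadiazol-2-yl for 4-phenyl-1,3-thiazol-2-yl reads a number 14 percentage points lower from compound 1 to compound 4 (beyond the scatter), so both thiazoles shown now lie beyond the scatter from the oxadiazole, a pattern that rests on only these compounds. The exchange from the thiadiazole reads a number 7.6 percentage points lower from compound 3 to compound 4 (within the scatter), which separates this thiazole from 5-phenyl-1,3,4-thiadiazol-2-yl less clearly than the other thiazole is separated from it. The two thiazoles themselves, differing in how the ring is attached and in the methyl group of 4-methyl-2-phenyl-1,3-thiazol-5-yl, cannot be told apart, with a step of a number 5.5 percentage points higher from compound 2 to compound 4 (within the scatter).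

As far as these compounds go, all four heteroaryl groups carry an unsubstituted phenyl and sit on the same single saturated chain carbon, so it remains open whether the thiazole effect would hold with an amine or a carboxylic acid on that phenyl, or with a longer chain in place of that carbon. Nothing at hand accounts for the separation of the thiazoles from the oxadiazole, which remains a plain observation at one concentration.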